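A few compounds are considered here, and "the series" means these few. Any claim that something is new, unique, unknown or untested is made for them only; others in the source may bear on it.

Working notes on the series. The shared core carries a branched group on the saturated chain carbon; in compound 1 `CCCn1c(=O)c2nc(C(C3CC3)C3CC3)[nH]c2n(CCC)c1=O` that carbon bears two cyclopropyl rings, and in an assay on cell membranes for binding affinity to adenosine receptor A1 (Cavia porcellus) (on this read-out lower numbers stand for stronger inhibition and higher numbers for weaker inhibition), compound 1 gives 3 nM. Compound 2 `CCCn1c(=O)c2nc(C(c3ccccc3)C3CC3)[nH]c2n(CCC)c1=O` has phenyl in place of one cyclopropyl and gives 150 nM; the step is a 50-fold higher number from compound 1 to compound 2 (1.70 log units; beyond the scatter). Compound 3 `CCCn1c(=O)c2nc(C(c3ccc(OC)cc3)C3CC3)[nH]c2n(CCC)c1=O` carries 4-methoxyphenyl instead and gives 250 nM, the step from the bis-cyclopropyl parent being an 83-fold higher number from compound 1 to compound 3 (1.92 log units; beyond the scatter). Between the two aryl compounds the change is small: a 1.7-fold higher number from compound 2 to compound 3 (0.22 log units; within the scatter). Compound 3 thus has the highest number of the three, but is separated from compound 2 only within the scatter and from compound 1 far beyond it.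

Compound 4 `CCCn1c(=O)c2nc(C(c3ccc(F)cc3)C3CC3)[nH]c2n(CCC)c1=O` is not yet measured. Its difference from compound 3 is fluoro in place of methoxy on an aromatic carbon. The large steps from compound 1 concern the exchange of cyclopropyl for an aryl ring and do not bear on a change within the aryl substituent. Within the data shown here, the only step that does, a 1.7-fold higher number from compound 2 to compound 3 (0.22 log units; within the scatter), lay within the scatter, so the exchange of one small group for another on the aryl ring is expected to move the number little, in no particular direction. The expected step is a 1.4-fold lower number from compound 3 to compound 4 (0.14 log units; within the scatter). Compound 4 is therefore estimated at 180 nM in this assay, with a range from 70 nM to 450 nM.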

Compound 4, inhibition constant: 250 nM
Compound 4: middle estimate off by 1.4-fold (0.14 log units), on the low side, within the range that was stated.
By their numbers in this assay, from the lowest: compound 1; then compounds 2, 3 and 4 (each within the scatter of the next).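

In this assay, fluoro in place of methoxy gives no change at the digits printed from compound 3 to compound 4 (within the scatter), and fluoro in place of hydrogen gives a 1.7-fold higher number from compound 2 to compound 4 (0.22 log units; within the scatter), so hydrogen, methoxy and fluoro on this aromatic carbon, para to a large group, now all stand within the scatter of one another. The earlier compounds shown here offered only one substituent on the aryl ring; compound 4 adds a second, with a single fluorine in place of the carbon and oxygen of methoxy, and the read-out does not separate the two. The gap to the bis-cyclopropyl parent also remains large, at an 83-fold higher number from compound 1 to compound 4 (1.92 log units; beyond the scatter), so among these compounds the large step goes with the aryl ring replacing cyclopropyl, and neither substituent shown on that ring narrows it beyond the scatter. No measurement in hand offers a reason for this flat response.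

From the compounds shown here alone, whether it extends to groups of another kind at this place, such as an amine, a carboxylic acid or a longer chain, stays open. Also open, going by these compounds, is whether a cyclohexyl ring in place of the aryl ring would give a number nearer that of compound 1 or nearer those of the aryl compounds.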